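A few compounds are considered here, and "the series" means these few. Any claim that something is new, unique, unknown or untested is made for them only; others in the source may bear on it.

Series notes. Compound 1 `N#Cc1ccc(Cn2cncc2CNc2ccc(C(=O)NCc3ccccc3)c(-c3ccccc3)c2)cc1` carries a benzyl group on the amide nitrogen of the shared core. In a functional assay on NIH3T3 cells (Mus musculus) (on this read-out higher numbers stand for an effect only at larger amounts of compound and lower numbers for an effect already at smaller amounts), compound 1 gives > 10 uM, which is a limit of the assay and not a number. Compound 2 `COC(=O)[C@H](CCSC)NC(=O)c1ccc(NCc2cncn2Cc2cccc(Cl)c2)cc1-c1ccccc1` in this assay also returns only a limit, > 10 uM. Compound 3 `CSCC[C@H](NC(=O)c1ccc(NCc2cncn2Cc2ccc(C)cc2)cc1-c1ccccc1)C(=O)O` stands at > 10 uM in this assay, again a limit. All three measured values sit at the limit of > 10 uM in this assay, at which 3 of the 3 values shown sit, so compound 1 cannot be placed relative to compound 2 or compound 3: every value shown for the series is a limit. For the measured compounds named here, no step between measured compounds that differ in one place can be drawn from these data.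

Compound 4 `N#Cc1ccc(Cn2cncc2CNc2ccc(C(=O)Nc3cccc(C#N)c3)c(-c3ccccc3)c2)cc1` is the next member to be measured. Relative to compound 1 the change is 3-cyanophenyl in place of benzyl on an amide-type nitrogen, the rest of the shared core being untouched. Going by the values given here, no value is a number; the change has no measured counterpart in this assay. The expected step of a number no higher from compound 1 to compound 4 (the limit leaves the size open) is small, with no direction beyond the scatter assumed, and the most probable outcome is a further limit. The estimate for compound 4 in this assay is 10 uM, with a range from 3 uM to 30 uM.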

Compound 4, concentration for half-maximal effect: > 10 uM
Compound 4 ended at the assay's limit; the forecaster's own chance of this, stated with the estimate: 75%; the middle value sits exactly at the limit.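

In this assay compound 4 gives > 10 uM, a limit of the assay and not a number. Compound 1 also stands at a limit, so no step between compound 1 and compound 4 can be read: the limit of > 10 uM in this assay, at which 4 of the 4 values shown sit.

The compounds shown leave open how any of the four ranks against the others in this assay.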